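A few compounds are considered here, and "the series" means these few. Any claim that something is new, unique, unknown or untested is made for them only; others in the source may bear on it.

For the measured compounds named here, compound 2, with the structure `Cc1cc(C)nc(Sc2ccc(NC(=O)Nc3ccccc3)cc2)n1`, is the only member of this small set to return a numerical value in a functional assay on MGC-803 cells (Homo sapiens) for cytotoxicity, read by MTT assay, with a stated time of 3 days (a higher number here means a weaker inhibitor, a lower number a stronger inhibitor), where compound 2 gives 40100 nM. Compound 1, the oxygen-linked analogue `Cc1cc(C)nc(Oc2ccc(NC(=O)Nc3ccc(F)cc3)cc2)n1`, stands apart in a sentence of its own: in this assay compound 1 reaches only the limit of > 50000 nM, which is a limit of the assay and not a number, as the line the limit of > 50000 nM in this assay, at which 1 of the 2 values shown sits, records. Going by the values given here, no single-change step between measured compounds is available, so the two values of compound 1 and compound 2 simply show one limit and one weak number.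

Compound 3, `Cc1cc(C)nc(Sc2ccc(NC(=O)Nc3ccc(F)cc3)cc2)n1`, is the untested partner of compound 2. The structural change is fluoro in place of hydrogen on an aromatic carbon, in words fluoro in place of hydrogen on an aromatic carbon, para to a large group. Nothing in the measured pair allows a step of a particular size or direction to be predicted for this change, and the expectation is for none beyond the usual scatter in this assay, expressed as a 1.1-fold higher number from compound 2 to compound 3 (0.05 log units; within the scatter). Compound 3 is accordingly estimated at 45000 nM, within a range from 18000 nM to 110000 nM, with a real chance that this assay again reports only a limit.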

Compound 3, half-maximal inhibitory concentration: > 50000 nM
Compound 3: no number, only a limit; the forecaster's own chance of this, stated with the estimate: 45%; middle value at least 1.1-fold (0.04 log units) from the limit.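

The fluoro group on this ring, para to a large group, does not bring compound 3 to a measurable value in this assay, and the change can be read only as a floor: an at least 1.2-fold higher number from compound 2 to compound 3 (0.09 log units; that floor lies within the scatter). On these data alone, compound 3 gives > 50000 nM, which is a limit of the assay and not a number, so the true size of the step stays unknown and no gain or loss from fluoro can be claimed beyond what that floor prints. The earlier compounds offered no step at this position, and this first one shows only that the single number in the set, held by compound 2, is not matched by its fluoro partner, while the limit has become the most frequent result: the limit of > 50000 nM in this assay, at which 2 of the 3 values shown sit.

Compound 1 and compound 3 differ only in the oxygen or sulfur link and both stop at a limit, so the compounds shown leave the effect of that link unresolved in this assay. They also leave open whether a different group at this same place, such as a methoxy, a chloro or an amine, would give a number clearly apart from that of compound 2.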